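This account rests on a few compounds, and the source may have more. Where it says the series, first, only, none or still open, it means among the compounds named here.

Of the compounds shown here, three have been measured in a functional assay on HCT-116 cells (Homo sapiens) for antiproliferative activity; on this read-out lower numbers stand for stronger inhibition and higher numbers for weaker inhibition. Compound 2 (`Cc1c2c(n3c1CCNC[C@@H](C)[C@H](C)Nc1cc-3ccc1C(N)=O)CC(C)(C)CC2=O`) gives 24 nM, within the scatter of compound 3 (`CC(=O)N1CCCc2c(C)c3c(n2-c2ccc(C(N)=O)c(c2)N[C@@H](C)[C@@H]1C)CC(C)(C)CC3=O`) at 27 nM, while compound 1 (`Cc1c2c(n3c1CCN(C(=O)[C@H](C)N)CC[C@H](C)Nc1cc-3ccc1C(N)=O)CC(C)(C)CC2=O`) gives 314 nM, a number beyond the scatter from compound 2. Compound 4 (`Cc1c2c(n3c1CCN(C(=O)[C@@H](N)C(C)C)C[C@@H](C)[C@H](C)Nc1cc-3ccc1C(N)=O)CC(C)(C)CC2=O`) carries (1-amino-2-methylpropyl)carbonyl in place of hydrogen on an amine nitrogen in a ring of compound 2 ((1-amino-2-methylpropyl)carbonyl in place of hydrogen on an amine nitrogen in a ring). Within the data shown here, no measured pair isolates this change. Compound 1, also bearing an amino-substituted acyl group on a ring nitrogen, gives 314 nM, and compound 3, bearing acetyl on a ring nitrogen, gives 27 nM. The expected change is a 5.0-fold higher number from compound 2 to compound 4 (0.70 log units; beyond the scatter), toward weaker inhibition and beyond the scatter. Compound 4 is estimated at 120 nM, with an expected range of 35 nM to 450 nM.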

Compound 4, half-maximal inhibitory concentration: 30 nM
Compound 4: the middle estimate sits 4.0-fold (0.60 log units) above what was measured, outside the stated range (below it).
By their numbers in this assay, from the lowest: compounds 2, 3 and 4 (each within the scatter of the next); then compound 1.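

In this assay, (1-amino-2-methylpropyl)carbonyl in place of hydrogen on the amine nitrogen in the ring gives a 1.3-fold higher number from compound 2 to compound 4 (0.10 log units; within the scatter) and so leaves the number within the scatter. Among these compounds, compound 1 and compound 3 each differ from compound 2 in more than one place, which leaves this as the only step that isolates an acyl group on this nitrogen. Nothing shown accounts for this result. Open, as far as these compounds go, is whether the acyl stereocentre matters, and whether a benzoyl group or a chain ending in a carboxylic acid on this nitrogen gives a similar number.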